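This account rests on a few compounds, and the source may have more. Where it says the series, first, only, none or still open, it means among the compounds named here.

In a functional assay on MDA-MB-231 cells (Homo sapiens) for cytotoxicity, read by MTT assay, with a stated time of 72 h (a higher number here means a weaker inhibitor, a lower number a stronger inhibitor), three compounds that share one core and differ only in the group on the amide-type nitrogen have been measured. Compound 1 `COc1ccc(NC(=O)CN2CCN(c3nnc(Cc4ccncc4)c4ccccc34)CC2)cc1OC` gives 100 nM, which places it in the middle of the three, since compound 2 `Cc1ccc(NC(=O)CN2CCN(c3nnc(Cc4ccncc4)c4ccccc34)CC2)c(C)c1` gives 240 nM and compound 3 `O=C(CN1CCN(c2nnc(Cc3ccncc3)c3ccccc23)CC1)Nc1cccc(F)c1` gives 4.4 nM.

Compound 4 `COc1ccc(NC(=O)CN2CCN(c3nnc(Cc4ccccc4)c4ccccc34)CC2)cc1OC` keeps the 3,4-dimethoxyphenyl group of compound 1 and changes a different place in the molecule: phenyl in place of pyridin-4-yl on a saturated chain carbon bound to an aromatic carbon.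

Within the data shown here, no measured step touches this place. All three available steps swap the group on the amide-type nitrogen: a 2.4-fold higher number from compound 1 to compound 2 (0.38 log units; beyond the scatter) is modest, while a 23-fold lower number from compound 1 to compound 3 (1.36 log units; beyond the scatter) and a 55-fold lower number from compound 2 to compound 3 (1.74 log units; beyond the scatter) are large. They bear on the new change only indirectly. They show that a single swap in this series can move the number a long way, so the range must be wide, but they give no direction for a swap made elsewhere. The expectation is therefore a small move towards a higher number, not clearly beyond the scatter. The estimated step is a 1.5-fold higher number from compound 1 to compound 4 (0.18 log units; within the scatter). For compound 4 the expected value is 150 nM, with an estimated range of 35 nM to 600 nM.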

Compound 4, half-maximal inhibitory concentration: 32200 nM
The estimate for compound 4 lay 210-fold (2.33 log units) below the measured number, and the stated range ends below it.
By their numbers in this assay, from the lowest: compound 3; then compound 1; then compound 2; then compound 4.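

In this assay, the group on the saturated chain carbon bound to an aromatic carbon turns out to matter a great deal: phenyl in place of pyridin-4-yl gives a 320-fold higher number from compound 1 to compound 4 (2.51 log units; beyond the scatter), although the swap leaves the count of heavy atoms unchanged and replaces only the ring nitrogen, the group's one hydrogen-bond acceptor, with carbon. This is the first step shown at this place, and it is larger than the largest step shown on the amide-type nitrogen, which is a 55-fold lower number from compound 2 to compound 3 (1.74 log units; beyond the scatter), so the amide group is not the only part of these compounds on which the number depends strongly. Nothing measured here accounts for the size of this step.

The compounds shown leave open whether the nitrogen must sit where it does in pyridin-4-yl, a question that pyridin-3-yl or pyridin-2-yl at this place would address, and whether a group such as pyrimidin-5-yl would behave like pyridin-4-yl or like phenyl. Going by these compounds, it also remains open whether the same swap would cost as much when carried out on the 3-fluorophenyl amide of compound 3 or the 2,4-dimethylphenyl amide of compound 2.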